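A few compounds are considered here, and "the series" means these few. Any claim that something is new, unique, unknown or untested is made for them only; others in the source may bear on it.

Going by the values given here, compound 1, `CC(C)N(CCN(C(=O)Nc1cc(Cl)nc(Cl)c1)C1CC[C@]2(c3cccc(C#N)c3)CC2C1)C(C)C`, is the stronger of the two measured members: in a functional assay for antagonist activity at melanin-concentrating hormone receptor 1 (Homo sapiens) (a higher number here means a weaker inhibitor, a lower number a stronger inhibitor), compound 1 gives 2.4 nM. Compound 2, `CNC(=O)N1CCC(CN(C(=O)Nc2ccc(F)c(C(F)(F)F)c2)C2CC[C@]3(c4cccc(C#N)c4)CC3C2)CC1`, carries a different urea aryl group and a different substituent on the other side, and in this assay compound 2 gives 181 nM, the highest number of the pair, with compound 1 lying well below it by a gap that exceeds the usual scatter. Compound 3, `CS(=O)(=O)N1CCC(CN(C(=O)Nc2ccc(F)c(C(F)(F)F)c2)C2CC[C@]3(c4cccc(C#N)c4)CC3C2)CC1`, differs from compound 2 in one place only: methylsulfonyl in place of methylcarbamoyl on an amine nitrogen in a ring. No measured pair shows the effect of this exchange, so there is nothing in the shown data to fix its direction. The step from compound 2 to compound 3 is therefore expected to be small, a 1.2-fold lower number from compound 2 to compound 3 (0.08 log units; within the scatter), and most likely within the scatter. On that basis compound 3 is estimated at 150 nM, with a range from 50 nM to 500 nM.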

Compound 3, inhibition constant: 26 nM
Compound 3: middle estimate off by 5.8-fold (0.76 log units), on the high side; measured number outside the range, below it.
By their numbers in this assay, from the lowest: compound 1; then compound 3; then compound 2.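

In this assay the group on the amine nitrogen of this six-membered non-aromatic ring clearly affects the read-out: methylsulfonyl in place of methylcarbamoyl gives a 7.0-fold lower number from compound 2 to compound 3 (0.84 log units; beyond the scatter) and so moves the number beyond the scatter. Going by these compounds alone, the earlier compounds could not show this, since they differ from each other in more than one place, whereas here the rest of the structure stays the same and only this group changes, with the hydrogen-bond donor of methylcarbamoyl lost and one more hydrogen-bond acceptor counted in methylsulfonyl. Nothing available explains why the exchange has this effect.

The compounds shown leave open whether an acetyl group, a dimethylcarbamoyl group or a longer sulfonyl such as ethylsulfonyl would follow methylsulfonyl or methylcarbamoyl on this nitrogen. They also leave open how an unsubstituted ring amine would read, and whether the step holds with another urea aryl group.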